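The source may report more compounds than this note shows. Statements on the series, on what has been measured and on what is new or still open speak of the compounds shown alone.

Measured so far in a functional assay on WI-38 VA13 cells (Homo sapiens) for cytotoxicity; a lower number here means that less compound is needed, a higher number that more compound is needed for the effect:
- compound 1 `CNc1c(C(=O)c2ccccc2)sc2nc(-c3cccs3)ccc12`: 0.42 ug/mL
- compound 2 `COc1ccc(OC)c(C(=O)c2sc3nc(-c4cccs4)ccc3c2N)c1`: 0.079 ug/mL
- compound 3 `CCOC(=O)c1sc2nc(-c3cccs3)ccc2c1N`: a limit only, > 4 ug/mL

Compound 3 stands apart from the other two in that its result in this assay is a limit of the measurement and not a number, > 4 ug/mL. One of the three values shown sits at that limit (the limit of > 4 ug/mL in this assay, at which 1 of the 3 values shown sits). Compound 1 and compound 2, the two aryl ketones on the shared core, both give a number in this assay, compound 1 at 0.42 ug/mL and compound 2 at 0.079 ug/mL.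

Compound 4 `COc1cccc(C(=O)c2sc3nc(-c4cccs4)ccc3c2N)c1` is the next entry. Compared with compound 3 the change is 3-methoxyphenyl in place of ethoxy on a carbonyl carbon, so compound 4 becomes an aryl ketone like compound 1 and compound 2 and keeps the primary amine of compound 3 and compound 2. Within the data shown here, no step between measured compounds is available for this exact change. On the pattern of compound 1 and compound 2 alone, a move from the limit to a number is expected, in the direction of a lower number and well beyond the scatter; the expected step is an at least 20-fold lower number from compound 3 to compound 4 (1.30 log units; beyond the scatter) in this assay. Compound 4 is therefore estimated at 0.2 ug/mL, within the range 0.05 ug/mL to 0.8 ug/mL.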

Compound 4, half-maximal effective concentration: 0.03 ug/mL
Estimate against measurement, compound 4: 6.7-fold (0.82 log units) above; the whole stated range lies above it.
By their numbers in this assay, from the lowest: compound 4; then compound 2; then compound 1. At a limit, above all of these: compound 3.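

In this assay compound 3 gives > 4 ug/mL, a limit of the assay and not a number: the limit of > 4 ug/mL in this assay, at which 1 of the 4 values shown sits.

As far as these compounds go, with the primary amine kept, 3-methoxyphenyl in place of ethoxy on a carbonyl carbon gives an at least 130-fold lower number from compound 3 to compound 4 (2.12 log units; beyond the scatter), so the group on this carbonyl carbon has a large effect on the number, and the true size of the step stays open at the limit. The aryl ketones also differ among themselves: hydrogen in place of methoxy on an aromatic carbon gives a 2.6-fold lower number from compound 2 to compound 4 (0.42 log units; beyond the scatter), so the substitution of the aryl ring changes the number too, though modestly.

From the compounds shown here alone, whether the aromatic ring itself is required remains open, as the ethoxy comparison cannot separate it from a cyclohexyl group or a longer alkyl chain on the same carbonyl carbon. Going by these compounds, how an amide or a carboxylic acid at this carbon would read in this assay also remains open.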